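Cytotoxicity in the series: piperidinyl to tetrahydroquinolinyl

The source may report more compounds than this note shows. Statements on the series, on what has been measured and on what is new or still open speak of the compounds shown alone.

Three compounds of the shared core have been run in an ADME assay on Vero cells (Chlorocebus sabaeus) for cytotoxicity, with a stated time of 7 days; a higher number here means that more compound is tolerated, a lower number that less compound is tolerated. Compound 1 `COc1ccc2[nH]c(C(=O)N3CC(=O)N(Cc4ccccc4)[C@@H](CN4CCCCC4)C3)cc2c1` gives 76900 nM. Compound 2 `O=C(c1cc2cc(C3CC3)ccc2[nH]1)N1CC(=O)N(Cc2ccccc2)[C@@H](CN2CCC(F)CC2)C1` gives 24500 nM. For compound 3 `COc1ccc2[nH]c(C(=O)N3CC(=O)N(c4ccccc4)[C@@H](Cc4ccccc4)C3)cc2c1` the read-out is a limit of the assay rather than a number, > 30000 nM; this is the only limit in the set, (the limit of > 30000 nM in this assay, at which 1 of the 3 values shown sits). Among the two numbers shown, compound 1 stands highest, and its gap to compound 2 lies beyond the usual scatter, so compound 1 is the better tolerated of the two measured compounds.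

Compound 4 `COc1ccc2[nH]c(C(=O)N3CC(=O)N(Cc4ccccc4)[C@@H](CN4CCCc5ccccc54)C3)cc2c1` has not yet been measured in this assay. Relative to compound 1 it carries 1,2,3,4-tetrahydroquinolin-1-yl in place of piperidin-1-yl on a saturated chain carbon bound to a saturated ring carbon. Within the data shown here, no measured pair in this set isolates that change, so no directly comparable step exists. The entering group is larger than the one it replaces, and on the data shown the expectation is a moderate step towards less tolerated compound, without confidence in its size. The step expected a 1.9-fold lower number from compound 1 to compound 4 (0.28 log units; within the scatter) is therefore a modest lowering. Compound 4 is expected to give 40000 nM in this assay, with a plausible range from 15000 nM to 100000 nM.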

Compound 4, half-maximal cytotoxic concentration: > 100000 nM
Compound 4: no number, only a limit; the forecaster's own chance of this, stated with the estimate: 20%; at least 2.5-fold (0.39 log units) between middle value and limit.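

In this assay the read-out of compound 4 is a limit of the assay and not a number, > 100000 nM. Replacing piperidin-1-yl with 1,2,3,4-tetrahydroquinolin-1-yl on a saturated chain carbon bound to a saturated ring carbon gives the first step readable at this place, an at least 1.3-fold higher number from compound 1 to compound 4 (0.11 log units; that floor lies within the scatter), so in this single pair the added six-membered aromatic ring of carbon only brings no loss of tolerance. For compound 4 the step can be read only as far as its floor, and its true size stays unknown because the read-out is a limit: the limit of > 100000 nM in this assay, at which 1 of the 4 values shown sits.

Among these compounds, this one pair sets no trend for the position, and compound 2 and compound 3 differ from compound 1 in more than one place, so they add no further step to it. Open questions are whether morpholin-4-yl or a dimethylamino group at this place would keep tolerance in this assay, and whether a carboxylic acid on the (piperidin-1-yl)methyl chain would change it.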